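A few compounds are considered here, and "the series" means these few. Any claim that something is new, unique, unknown or untested is made for them only; others in the source may bear on it.

In a functional assay on KARPAS-422 cells (Homo sapiens) for inhibition, with a stated time of 72 h (on this read-out lower numbers stand for stronger inhibition and higher numbers for weaker inhibition), compound 1 `Cc1cc(C)c(CN2CCc3ccc(-c4c(C)noc4C)c(Cl)c3C2=O)c(=O)[nH]1` gives 121 nM, while compound 2 `Cc1cc(C)c(CN2CCc3c(Cl)cc(-c4c(C)n[nH]c4C)c(Cl)c3C2=O)c(=O)[nH]1` gives 959 nM, the higher of the two numbers. Compound 3 `Cc1cc(C)c(CN2CCc3c(Cl)cc(-c4c(C)noc4C)c(Cl)c3C2=O)c(=O)[nH]1` differs from compound 2 at one place: 3,5-dimethyl-1,2-oxazol-4-yl in place of 3,5-dimethyl-1H-pyrazol-4-yl on an aromatic carbon. It has 3,5-dimethyl-1,2-oxazol-4-yl in place of 3,5-dimethyl-1H-pyrazol-4-yl on an aromatic carbon. Within the data shown here, no measured pair isolates this change. Compound 1, which also carries 3,5-dimethyl-1,2-oxazol-4-yl, gives 121 nM, so a move to a lower number in this assay, beyond the scatter, is expected. The expected step is a 3.8-fold lower number from compound 2 to compound 3 (0.58 log units; beyond the scatter). For compound 3 the estimated value is 250 nM, with an expected range of 80 nM to 800 nM.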

Compound 3, half-maximal inhibitory concentration in the KARPAS-422 assay: 25 nM
Compound 3: middle estimate off by 10-fold (1.00 log units), on the high side; the measured number lies below the stated range.
By their numbers in the KARPAS-422 assay, from the lowest: compound 3; then compound 1; then compound 2.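

In the KARPAS-422 assay, compound 2 gives 959 nM and compound 3 gives 25 nM; 3,5-dimethyl-1,2-oxazol-4-yl in place of 3,5-dimethyl-1H-pyrazol-4-yl gives a 38-fold lower number from compound 2 to compound 3 (1.58 log units; beyond the scatter), so this aromatic carbon separates the two rings sharply. With 3,5-dimethyl-1,2-oxazol-4-yl kept, the KARPAS-422 assay shows that chloro in place of hydrogen gives a 4.8-fold lower number from compound 1 to compound 3 (0.68 log units; beyond the scatter), so the added chloro is tolerated. In a physicochemical assay for lipophilicity, at pH 7.4 (a lower number here means a more polar compound, a higher number a more lipophilic compound), compound 2 gives 3.4 and compound 3 gives 3.1; the ring change gives a number 0.30 log units lower from compound 2 to compound 3 (within the scatter), so this read-out does not separate the pair.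

Nothing available explains the difference between the two rings. Going by these compounds, how a morpholine or a carboxylic acid would fare at this aromatic carbon remains open.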